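The source may report more compounds than this note shows. Statements on the series, on what has been measured and on what is new or still open speak of the compounds shown alone.

Compound 1 `COc1cc(/C=C2\CCC/C(=C\c3ccccc3[N+](=O)[O-])C2=O)cc(OC)c1OC`: 35000 nM
Compound 2 `COc1ccc(/C=C2\CCC/C(=C\c3ccc([N+](=O)[O-])cc3)C2=O)cc1`: > 400000 nM

Among the compounds with values here, in an ADME assay on HPC cells (Homo sapiens) for cytotoxicity, with a stated time of 24 h (on this read-out lower numbers stand for higher toxicity in this test and higher numbers for lower toxicity in this test), compound 1 gives 35000 nM, the only exact number so far. The entry for compound 2 is a limit of the assay, not a number. Compound 3 `COc1cc(/C=C2\CCC/C(=C\c3ccc([N+](=O)[O-])cc3)C2=O)cc(OC)c1OC` has 4-nitrophenyl in place of the 2-nitrophenyl of compound 1 (4-nitrophenyl in place of 2-nitrophenyl on a double-bonded chain carbon bound to a double-bonded ring carbon). Within the data shown here, no measured pair isolates this swap. A moderate rise in this assay, meaning lower toxicity in this test, is expected, since compound 2, which also carries 4-nitrophenyl but differs elsewhere, reads > 400000 nM. The expected change is a 2.0-fold higher number from compound 1 to compound 3 (0.30 log units; within the scatter). For compound 3 the estimated value is 70000 nM, within an expected range of 20000 nM to 300000 nM.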

Compound 3, half-maximal cytotoxic concentration in the HPC assay: 347000 nM
Beside the measured number, compound 3's estimate is 5.0-fold (0.70 log units) below it, and the stated range ends below it.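

In the HPC assay, compound 1 gives 35000 nM and compound 3 gives 347000 nM. In the HPC assay, 4-nitrophenyl in place of 2-nitrophenyl gives a 9.9-fold higher number from compound 1 to compound 3 (1.00 log units; beyond the scatter), so with the same atoms joined differently, this single change on the double-bonded chain carbon already moves the read-out towards lower toxicity in this test. In a physicochemical assay for lipophilicity (a lower number here means a more polar compound, a higher number a more lipophilic compound), compound 1 gives 4.33 and compound 3 gives 4.56. In the physicochemical assay, the same swap gives a number 0.23 log units higher from compound 1 to compound 3 (within the scatter), so this read-out does not separate the two compounds. Compound 2 also carries 4-nitrophenyl, but its entry is a limit of the assay, not a number: the limit of > 400000 nM in the HPC assay, at which 1 of the 3 values shown sits.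

Still open, as far as these compounds go, is how a phenyl carrying an amine or a carboxylic acid in place of 4-nitrophenyl would read.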